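The compounds below may be only part of what the source reports. "The series", "measured", "known", "first", "only" and "open" are said of these compounds alone.

Compound 3 `COc1cc(CC2C(C#N)=C(N)N(c3ccc(S(N)(=O)=O)cc3)C3=C2C(=O)CCC3)ccc1O` stands second highest of the three compounds measured in a functional assay on Ehrlich cells (Mus musculus) for antiproliferative activity, read by trypan blue exclusion, with a stated time of 2 h, tested at 50 ug/mL (on this read-out higher numbers stand for a stronger effect at the one concentration tested and lower numbers for a weaker effect), where compound 3 gives 90%. Its nearest neighbour is compound 2 `N#CC1=C(N)N(c2ccc(S(N)(=O)=O)cc2)C2=C(C(=O)CCC2)C1c1ccc(O)cc1`, which in this assay gives 100%; the furthest is compound 1 `N#CC1=C(N)N(c2ccc(S(N)(=O)=O)cc2)C2=C(C(=O)CCC2)C1c1ccccc1`, which gives 40%.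

Compound 4 `N#CC1=C(N)N(c2ccc(S(N)(=O)=O)cc2)C2=C(C(=O)CCC2)C1c1c(O)ccc2ccccc12` differs from compound 3 in one place: 2-hydroxynaphthalen-1-yl in place of 4-hydroxy-3-methoxybenzyl on a saturated ring carbon.

Within the data shown here, three measured steps bear on this change. The replacement of phenyl by 4-hydroxy-3-methoxybenzyl produced a number 50 percentage points higher from compound 1 to compound 3 (beyond the scatter), and the introduction of a hydroxy group on an aromatic carbon produced a number 60 percentage points higher from compound 1 to compound 2 (beyond the scatter), both large. Between the two hydroxy-bearing groups the step was a number 10 percentage points lower from compound 2 to compound 3 (within the scatter), within the scatter. Compound 4 keeps a hydroxy group on the entering aryl, so the expected step in this assay is small, with no direction beyond the scatter; if anything, the value of compound 4 is expected to sit between those of compound 2 and compound 3, both of which carry a hydroxy group. Compound 4 is therefore estimated at 88%, with a range from 65% to 100%, which means an expected step of a number 2 percentage points lower from compound 3 to compound 4 (within the scatter).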

Compound 4, a percentage reported as activity, at one concentration (the size of the read-out at that concentration, not a potency): 5%
Beside the measured number, compound 4's estimate is 83 percentage points above it, and the stated range ends above it.
By their numbers in this assay, from the lowest: compound 4; then compound 1; then compounds 3 and 2 (each within the scatter of the next).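

At this saturated ring carbon, a hydroxy group on the entering aryl proved no guarantee of a strong effect in this assay: 2-hydroxynaphthalen-1-yl gives a number 85 percentage points lower from compound 3 to compound 4 (beyond the scatter) and a number 95 percentage points lower from compound 2 to compound 4 (beyond the scatter). The change also falls short of the unsubstituted phenyl group, with a number 35 percentage points lower from compound 1 to compound 4 (beyond the scatter), whereas the two other hydroxy-bearing groups had both stood well above phenyl, so a hydroxy-bearing aryl at this position can go either way. No measurement among the data shown accounts for this drop.

On these data alone, it remains open whether the loss goes with the second aromatic ring of the entering group or with the place of its hydroxy group, a question that a 2-hydroxyphenyl group or an unsubstituted naphthalen-1-yl group on this carbon would help to settle. Also open, as far as these compounds go, is how an amine or a carboxylic acid would read on the aryl ring in place of the hydroxy group, and whether the 4-hydroxy-3-methoxybenzyl result would hold with a longer chain between the ring carbon and the aryl.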